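A few compounds are considered here, and "the series" means these few. Any claim that something is new, unique, unknown or untested is made for them only; others in the source may bear on it.

Compound 1 `CC1=C(C(=O)OC(C)C)C(c2ccccc2)N/C(=N/C#N)N1` gives 6% in an assay on HeLa cells for displacement of a labelled ligand from adenosine receptor A3 (Homo sapiens), with a stated time of 180 min, tested at 1 uM; a lower number here means less inhibition, a higher number more inhibition at the concentration tested (going by the name of the read-out).
Compound 2 `CC1=C(C(=O)OC(C)C)C(c2ccco2)N/C(=N/C#N)N1` gives 4% in this assay.
Compound 3 `CCOC(=O)C1=C(C)N/C(=N\C#N)NC1c1ccoc1` gives 14% in this assay.

Compound 3 stands at the top of these three numbers, yet its gap to compound 1 and its gap to compound 2 both lie within the usual scatter of this assay, so no real order among the three can be read from them. Among the measured compounds shown here, the one measured step with a single change, a number 2 percentage points lower from compound 1 to compound 2 (within the scatter), concerns the ring on the saturated ring carbon, not the ester.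

Compound 4 `CC1=C(C(=O)OC(C)C)C(c2ccoc2)N/C(=N/C#N)N1` differs from compound 3 by methyl in place of hydrogen on a saturated chain carbon bound to an oxygen next to a carbonyl group and a saturated chain carbon. For the measured compounds named here, no measured pair shows this change, so nothing in the data bears directly on it; the only step available is small and of another kind. On that basis the step from compound 3 to compound 4 is expected to stay within the scatter, as a number 2 percentage points lower from compound 3 to compound 4 (within the scatter). For compound 4 the estimated inhibition in this assay is 12%, with a range from 2% to 24%.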

Compound 4, a percentage reported as inhibition, at one concentration (the size of the read-out at that concentration, not a potency): 41%
Compound 4: middle estimate off by 29 percentage points, on the low side; the measured number lies above the stated range.
By their numbers in this assay, from the lowest: compounds 2, 1 and 3 (each within the scatter of the next); then compound 4.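

Ethyl to isopropyl on the ester, that is methyl in place of hydrogen on the saturated chain carbon bound to an oxygen, gives a number 27 percentage points higher from compound 3 to compound 4 (beyond the scatter) in this assay, so this position, on which no earlier pair bore, can move the number when furan-3-yl is the ring on the saturated ring carbon. Among the compounds shown here, with the isopropoxycarbonyl group held, the ring also counts: the read-out shows a number 37 percentage points higher from compound 2 to compound 4 (beyond the scatter) and a number 35 percentage points higher from compound 1 to compound 4 (beyond the scatter), whereas the only earlier ring change gave a number 2 percentage points lower from compound 1 to compound 2 (within the scatter). Nothing available explains these steps.

The compounds shown leave open whether ethyl to isopropyl has the same effect with phenyl or furan-2-yl on the saturated ring carbon. They also leave open what a tert-butyl ester, a longer chain such as n-butyl on the ester, or a thiophen-3-yl ring would give.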